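The compounds below may be only part of what the source reports. "The series", "measured", "known", "first", "only" and "open" are said of these compounds alone.

Of the compounds shown here, three sharing the same core have been tested in an assay on isolated protein for inhibition of Flap endonuclease 1 (Homo sapiens); on this read-out higher numbers stand for weaker inhibition and lower numbers for stronger inhibition. Compound 1 `O=C(O)C(=O)CC(=O)c1ccc(-c2ccccc2)cc1` gives 3500 nM. Compound 2 `Cc1ccccc1C(=O)CC(=O)C(=O)O` gives 12900 nM. Compound 3 `O=C(O)C(=O)CC(=O)c1cccc(Cl)c1` gives 6960 nM, which places it second highest of the three numbers; its nearest neighbour is compound 2, and the gap between them lies within the usual scatter, as does the gap to compound 1, the furthest of the three. Going by the values given here, no change at a single place links any two of these measured compounds, so no measured step can be used as a guide.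

Compound 4 `O=C(O)C(=O)CC(=O)c1cccc(Oc2ccccc2)c1` has not yet been measured in this assay. It arises from compound 3 by a change at a single place: phenoxy in place of chloro on an aromatic carbon. Among the compounds with values here, the compounds seen so far all sit within the scatter of one another, so there is no measured step that tells how much a larger group at this position shifts the number. What can be said is that compound 1, which also carries an extra aromatic ring, gives the lowest of the three numbers at 3500 nM, though within the scatter of compound 3.

On this basis compound 4 is expected to show a small step downward, a 2.0-fold lower number from compound 3 to compound 4 (0.30 log units; within the scatter), of a size that barely exceeds the scatter if at all. The estimate for compound 4 is 3500 nM, with a range from 1200 nM to 10000 nM.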

Compound 4, half-maximal inhibitory concentration: 7310 nM
For compound 4 the middle estimate is 2.1-fold (0.32 log units) below the measured one; the range from low to high includes it.
By their numbers in this assay, from the lowest: compounds 1, 3, 4 and 2 (each within the scatter of the next, the first and the last beyond it).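

Replacing chloro with phenoxy on this aromatic carbon in this assay gives a 1.1-fold higher number from compound 3 to compound 4 (0.02 log units; within the scatter), so the two numbers cannot be told apart. This shows that the place can carry a far larger group, 7 heavy atoms and a whole six-membered aromatic ring in place of a single chlorine, without any change in the number that stands out from the usual scatter of the measurement. Going by these compounds alone, the earlier compounds offered no step at a single place, so this is the first direct reading of what a change here does, and nothing available explains why the added ring and hydrogen-bond acceptor leave the number where it was.

The compounds shown leave open whether a group of another kind at this place, such as an amine or a carboxylic acid, would move the number beyond the scatter. They also leave open whether plain hydrogen here, or a longer chain linking the second ring to the oxygen of the phenoxy group, would give a number that differs from those of compound 3 and compound 4.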